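This account rests on a few compounds, and the source may have more. Where it says the series, first, only, none or still open, it means among the compounds named here.

Measured in a functional assay on HepG2 cells (Homo sapiens) for antiproliferative activity, read by MTT assay, with a stated time of 72 h; a higher number here means a weaker inhibitor, a lower number a stronger inhibitor:
compound 1 `CC(C)N1C(=O)COc2ccc(-c3cccc(NS(=O)(=O)c4ccc(F)cc4)c3)cc21`: > 40000 nM (a limit)
compound 2 `COc1ncc(-c2ccc3c(c2)N(C2CC2)C(=O)CO3)cc1NS(=O)(=O)c1ccc(F)cc1`: 14400 nM
compound 3 `O=C1COc2ccc(-c3cnc4ccccc4c3)cc2N1c1ccc(F)cc1`: 37200 nM

Compound 1 has no number, only a limit: it stands at the limit of > 40000 nM in this assay, at which 1 of the 3 values shown sits. Within the data shown here, no two measured compounds differ in one place, so no measured step bears directly on the next change.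

Compound 4 `COc1ccc(N2C(=O)COc3ccc(-c4cccc(NS(=O)(=O)c5ccc(F)cc5)c4)cc32)cc1` keeps the rest of compound 1 and carries 4-methoxyphenyl in place of isopropyl on an amide-type nitrogen in a ring. The nearest guide is thin. Compound 3 also has an aromatic ring on the amide-type nitrogen, although the rest of it differs, and compound 3 gives 37200 nM. On that single value, a small step is expected in this assay, toward a lower number if there is one, and it may not exceed the scatter. Compound 4 could also read only as a limit.

The expected change is an at least 1.3-fold lower number from compound 1 to compound 4 (0.12 log units; that floor lies within the scatter). For compound 4 the estimated value is 30000 nM, with an expected range from 10000 nM to 60000 nM.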

Compound 4, half-maximal inhibitory concentration: 29800 nM
Beside the measured number, compound 4's estimate is 1.0-fold (0.00 log units) above it, within the range that was stated.
By their numbers in this assay, from the lowest: compound 2; then compounds 4 and 3 (each within the scatter of the next). At a limit, above all of these: compound 1.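

In this assay, 4-methoxyphenyl in place of isopropyl on the amide-type nitrogen in a ring gives the first step readable at this position: an at least 1.3-fold lower number from compound 1 to compound 4 (0.12 log units; that floor lies within the scatter). The core of compound 1 reaches a measured number with 4-methoxyphenyl in this place, as compound 4 gives 29800 nM. The true size of the step cannot be read, because compound 1 has no number, only a limit: the limit of > 40000 nM in this assay, at which 1 of the 4 values shown sits.

The compounds shown leave open whether the measurable reading goes with the aromatic ring itself or with its methoxy group, a question that plain phenyl on the same nitrogen would address. They also leave open how this position responds to a different kind of group, such as a longer chain ending in a dimethylamine or a carboxylic acid.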